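Sulfanyl chain variation on the shared core

The compounds below may be only part of what the source reports. "The series", "measured", "known", "first", "only" and "open" are said of these compounds alone.

Two compounds of the series have numbers in a functional assay on Fem-X cells (Homo sapiens) for cytotoxicity; on this read-out higher numbers stand for weaker inhibition and lower numbers for stronger inhibition. Compound 1 `CCCCSC1=CC(=O)C(C[C@]2(C)[C@@H](C)CC[C@]3(C)C(C)=CCC[C@@H]23)=CC1=O` gives 24400 nM in this assay. Compound 2 `COC1=CC(=O)C=C(C[C@]2(C)[C@@H](C)CC[C@]3(C)C(C)=CCC[C@@H]23)C1=O` differs from compound 1 in several places. In this assay compound 2 gives 9800 nM. Compound 1 thus holds the higher of the two numbers, and the gap to compound 2 lies beyond the usual scatter. Going by the values given here, no step between measured compounds differing in a single place is available.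

Compound 3 `CC1=CCC[C@H]2[C@](C)(CC3=CC(=O)C(SC(C)C)=CC3=O)[C@@H](C)CC[C@]12C` is the next analogue. From compound 1 it differs as follows: isopropyl in place of butyl on a sulfur. The change is confined to the chain on the sulfur. With no measured step of this kind in the series to lean on, the expected step of a 1.2-fold lower number from compound 1 to compound 3 (0.09 log units; within the scatter) is small, without a clear direction, and likely within the scatter. Compound 3 is accordingly expected to give about 20000 nM in this assay, within a range from 8000 nM to 50000 nM.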

Compound 3, half-maximal inhibitory concentration: 86000 nM
For compound 3 the middle estimate is 4.3-fold (0.63 log units) below the measured one; measured number above the stated range.
By their numbers in this assay, from the lowest: compound 2; then compound 1; then compound 3.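

In this assay the chain on the sulfur proves to be a position that responds to change: isopropyl in place of butyl brings a 3.5-fold higher number from compound 1 to compound 3 (0.55 log units; beyond the scatter). Going by these compounds alone, this is the first single-place step, and it runs toward weaker inhibition, so butylsulfanyl is the better of the two chains on the shared core. No measurement at hand accounts for the shift.

From the compounds shown here alone, with a single step, it stays open whether chain length, branching or both govern this change, as butyl and isopropyl differ in both. A straight propyl chain on the sulfur would separate the two, while a longer chain such as octyl, or a chain ending in an amine or a carboxylic acid, would test how much the position tolerates.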